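Swapping the sulfonamide amine in a pancreatic cancer cell series

The compounds below may be only part of what the source reports. "The series", "measured", "known", "first", "only" and "open" are said of these compounds alone.

Compound 1 `CCN(CC)S(=O)(=O)c1ccc(S(=O)(=O)N2CCC[C@@H](C(=O)N3CCC(F)(F)CC3)C2)cc1` carries a diethylsulfamoyl group on its aromatic ring. In a functional assay on MIA PaCa-2 cells (Homo sapiens) for inhibition, read by MTT assay, with a stated time of 7 days (a lower number here means a stronger inhibitor, a higher number a weaker inhibitor), compound 1 gives 16 nM, the lowest of the two numbers in hand. Among the measured compounds shown here, its only measured neighbour, compound 2 `CCN(CC)S(=O)(=O)c1ccc(S(=O)(=O)N2CCC[C@@H](C(=O)N[C@H]3CC[C@H](OC)CC3)C2)cc1`, differs on the carbonyl carbon and gives 1350 nM in this assay, so the step of an 84-fold higher number from compound 1 to compound 2 (1.93 log units; beyond the scatter) shows that the amide end of the shared core is very sensitive to change.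

Compound 3 `CC(C)NS(=O)(=O)c1ccc(S(=O)(=O)N2CCC[C@@H](C(=O)N3CCC(F)(F)CC3)C2)cc1` keeps the amide of compound 1 untouched and alters the other end instead: isopropylamino in place of diethylamino on a sulfonyl sulfur. For the measured compounds named here, this is the first change at the sulfonyl sulfur, so the step from compound 1 to compound 2 does not bear on it directly; it only shows that large movements are possible elsewhere on the core. Nothing measured speaks to the diethylsulfamoyl-to-isopropylsulfamoyl exchange itself, so the expectation rests on the change alone: a small loss or none beyond the scatter, a 1.9-fold higher number from compound 1 to compound 3 (0.27 log units; within the scatter) being the expected step. Compound 3 is therefore estimated at 30 nM, within a range of 8 nM to 120 nM.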

Compound 3, half-maximal inhibitory concentration: 350 nM
Compound 3: the middle estimate sits 12-fold (1.07 log units) below what was measured; the whole stated range lies below it.
By their numbers in this assay, from the lowest: compound 1; then compound 3; then compound 2.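

In this assay, the end of the core carrying the sulfonyl sulfur proves to be sensitive too: with the amide of compound 1 left unchanged, the step of a 22-fold higher number from compound 1 to compound 3 (1.34 log units; beyond the scatter) shows that the amide end is not the only place where a single change matters. The exchange looks modest on paper, with diethylamino (5 heavy atoms, 0 hydrogen-bond donors) giving way to isopropylamino (4 heavy atoms, 1 hydrogen-bond donor), so a small edit to this group can still move the number far beyond the scatter. Nothing at hand explains which of these differences, if either, lies behind the loss.

The compounds shown cannot separate the hydrogen on the sulfonamide nitrogen from the change of chain, a question that methyl(isopropyl)amino, which keeps the isopropyl group without that hydrogen, or ethylamino, which keeps the hydrogen with a different chain, could address. They also leave open whether isopropylamino would have a similar effect alongside the (4-methoxycyclohexyl)amino group of compound 2, since the two changes appear here only separately.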